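The source may hold more compounds than are shown below. What is called first, only, known or untested is meant among the compounds shown, and "the series" means these compounds.

Compound 1 `CCn1nnc(-c2sc(-c3cccc(N(C)C)c3)nc2O)n1` carries a dimethylamino group on its phenyl ring and sits at the upper end of the numbers measured here. In an assay on HEK293 cells for inhibition of transient receptor potential cation channel subfamily M member 8 (Homo sapiens), read by FLIPR, with stated times of 5 min and 3 min (on this read-out lower numbers stand for stronger inhibition and higher numbers for weaker inhibition), compound 1 gives 4770 nM. Compound 2 `O=C(c1sc(-c2cccc(F)c2)nc1O)N1CCCCO1`, which instead carries a fluoro-substituted ring and a cyclic amide in place of the triazole, gives 167 nM in this assay, so compound 1 has the higher of the two numbers and compound 2 the lower, a gap that lies well beyond the usual scatter. Compound 3 `CCn1nnnc1-c1sc(-c2cccc(F)c2)nc1O`, with the tetrazole variant of the ring system and the same fluoro ring, reaches only the limit of the assay, > 100000 nM, and no number is recorded for it (the limit of > 100000 nM in this assay, at which 1 of the 3 values shown sits).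

The step of interest leads from compound 1 to compound 4 `CCn1nnc(-c2sc(-c3cccc(O)c3)nc2O)n1`, in which a hydroxy replaces the dimethylamino on the phenyl ring (hydroxy in place of dimethylamino on an aromatic carbon); the rest of the molecule is unchanged. No measured pair among the compounds shown makes exactly this exchange, so the expected effect has to be framed loosely: compound 1 is already weak, and the replacement is small. Compound 4 is therefore expected to remain in the same weak region, with an estimated value of 5000 nM and a plausible range from 1500 nM to 20000 nM. This means the step from compound 1 to compound 4 is expected to be a 1.0-fold higher number from compound 1 to compound 4 (0.02 log units; within the scatter), that is, no change beyond the scatter in this assay.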

Compound 4, half-maximal inhibitory concentration: 239 nM
For compound 4 the middle estimate is 21-fold (1.32 log units) above the measured one; measured number below the stated range.
By their numbers in this assay, from the lowest: compounds 2 and 4 (each within the scatter of the next); then compound 1. At a limit, above all of these: compound 3.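

In this assay, replacing dimethylamino with hydroxy on an aromatic carbon of the six-membered aromatic ring of carbon only, meta to a large group, gives a 20-fold lower number from compound 1 to compound 4 (1.30 log units; beyond the scatter). The earlier compounds shown here differ from one another in more than one place, so they could not isolate this position; this pair shows that the exchange of this one group, with the rest of the molecule unchanged, is enough to produce a large step in this read-out. No measured property among the data shown bears on why the number falls so far.

On these data alone, it remains open whether the step follows from the arrival of hydroxy, with its hydrogen-bond donor, or from the departure of dimethylamino, and a methoxy group or a primary amine on the same aromatic carbon would help to separate the two. The compounds shown also leave open how a carboxylic acid or a longer chain at this position would read in this assay, and whether the same exchange would give a step of similar size on the other cores shown here.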